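Removing the Pyrazole Ring from Compound 3

A few compounds are considered here, and "the series" means these few. Any claim that something is new, unique, unknown or untested is made for them only; others in the source may bear on it.

Of the compounds shown here, three have been tested in a functional assay on CHO cells for agonist activity at Alpha-1B adrenergic receptor (Homo sapiens), read by FLIPR and calcium flux; a lower number here means that less compound is needed, a higher number that more compound is needed for the effect. Compound 1 `CS(=O)(=O)Nc1cccc2c1CCC2c1ncc[nH]1` gives only a limit of the assay, > 10000 nM. Compound 2 `Cc1c(OCC2=NCCN2)ccc(Cl)c1NS(C)(=O)=O` likewise gives only a limit, > 10000 nM. Compound 3 `Cn1cc(-c2cccc3c2CCC3c2ncc[nH]2)cn1` also gives only a limit, > 10000 nM. Because (the limit of > 10000 nM in this assay, at which 3 of the 3 values shown sit), compound 3 cannot be placed higher or lower than the other two compounds; all three sit at the same edge of what this assay can measure. For the measured compounds named here, the one step between measured compounds that differ in a single place, a step that the two limits leave unreadable from compound 1 to compound 3, is unreadable for the same reason, so its size is unknown.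

Compound 4 `c1ccc2c(c1)CCC2c1ncc[nH]1` has not yet been measured. hydrogen in place of 1-methyl-1H-pyrazol-4-yl on an aromatic carbon The shared core of compound 3 is kept, and the 1-methyl-1H-pyrazol-4-yl group on the six-membered aromatic ring is replaced by hydrogen. Going by the values given here, no measured step bears directly on this change, and the only measured step gives no size at all, so there is no basis for expecting movement beyond the scatter in either direction. The step from compound 3 to compound 4 is therefore expected to be a step that the limit leaves unreadable from compound 3 to compound 4, with wide uncertainty. Compound 4 is estimated at 15000 nM, in a range from 2000 nM to 100000 nM, and most likely it too will return only a limit.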

Compound 4, half-maximal effective concentration: > 10000 nM
Compound 4: no number, only a limit; the forecaster's own chance of this, stated with the estimate: 70%; the middle value lies beyond the limit too.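

In this assay compound 4 gives > 10000 nM as a limit of the assay, not a number. The steps from compound 3 to compound 4 and from compound 1 to compound 4 cannot be read, because every value shown is the same limit: the limit of > 10000 nM in this assay, at which 4 of the 4 values shown sit. The compounds shown leave open what concentration, if any, produces agonist activity with each of these groups on the shared core.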